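Cyclopentyl Enters Where Methyl Stood

This account rests on a few compounds, and the source may have more. Where it says the series, first, only, none or still open, it means among the compounds named here.

Compound 2 `CCC(=O)c1ccc(OCCCCOc2ccc(C(=O)O)cc2C)c(C)c1O` stands at the lower of the two numbers in an assay on HEK293 cells for positive allosteric modulation of metabotropic glutamate receptor 3 (Rattus norvegicus), read by thallium flux, with a stated time of 2.5 min (on this read-out higher numbers stand for larger maximal responses and lower numbers for smaller maximal responses), where compound 2 gives 22.7%; compound 1 `Cc1cc(C(=O)O)ccc1OCCCCOc1ccc(C(=O)CC(C)C)c(O)c1C` gives 42.1%. For the measured compounds named here, the one measured step that bears on the new change is a number 19.4 percentage points lower from compound 1 to compound 2 (beyond the scatter), a modest fall when the smaller group replaced the larger one at the same place. Compound 3 `Cc1cc(C(=O)O)ccc1OCCCCOc1ccc(C(=O)CC2CCCC2)c(O)c1C` differs from compound 2 by cyclopentyl in place of methyl on a saturated chain carbon bound to a carbonyl carbon. Because a number 19.4 percentage points lower from compound 1 to compound 2 (beyond the scatter) pairs the larger group with the larger maximal response, compound 3 is expected to rise by a number 19.3 percentage points higher from compound 2 to compound 3 (beyond the scatter). Compound 3 is therefore estimated at 42%, within a range of 25% to 60%.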

Compound 3, largest response reached (reported as percent of maximum), in percent of the reference or control that the assay uses: 28.4%
For compound 3 the middle estimate is 13.6 percentage points above the measured one, within the range that was stated.
By their numbers in this assay, from the lowest: compounds 2 and 3 (each within the scatter of the next); then compound 1.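

At this place, on a saturated chain carbon bound to a carbonyl carbon, cyclopentyl brings a number 5.7 percentage points higher from compound 2 to compound 3 (within the scatter) and so leaves compound 3 level with compound 2 in spite of its 5 heavy atoms against 1 for methyl. The link between a larger group and a larger maximal response that isopropyl suggested therefore does not extend to this ring, as a number 13.7 percentage points lower from compound 1 to compound 3 (beyond the scatter) shows. No evidence is at hand to explain this result.

The compounds shown leave open whether a longer chain or a cyclohexyl ring here would match compound 1 or stay level with compound 2 and compound 3.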